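The source may hold more compounds than are shown below. What is called first, only, known or untested is meant among the compounds shown, and "the series" means these compounds.

Measured compounds:
compound 1, `Cc1cc(C(=O)NCN2CCC(c3cccc[n+]3[O-])CC2)ccc1F`: 50 nM
compound 2, `C=Cc1cccc(C(=O)NCN2CCC(c3cccc[n+]3[O-])CC2)c1`: 68 nM
compound 3, `Cc1cccc(C(=O)NCN2CCC(c3cccc[n+]3[O-])CC2)c1`: 89 nM

All three numbers come from a functional assay on HEK293 cells for agonist activity at D(4) dopamine receptor (Homo sapiens), read by FLIPR; on this read-out higher numbers stand for an effect only at larger amounts of compound and lower numbers for an effect already at smaller amounts. Compound 3 gives the highest of the three numbers in this assay, but its steps from the other two stay within the scatter: a 1.8-fold higher number from compound 1 to compound 3 (0.25 log units; within the scatter) and a 1.3-fold higher number from compound 2 to compound 3 (0.12 log units; within the scatter). Compound 1 and compound 2 likewise lie within the scatter of each other, a 1.4-fold higher number from compound 1 to compound 2 (0.13 log units; within the scatter). The three measured compounds are thus not separated on this read-out.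

Compound 4, `COc1ccccc1C1CCN(CNC(=O)c2cccc(C)c2)CC1`, differs from compound 3 at another place in the shared core: a group of 8 heavy atoms (7 carbon, 1 oxygen; one six-membered aromatic ring of carbon only) in place of a group of 7 heavy atoms (5 carbon, 1 nitrogen, 1 oxygen; one six-membered aromatic ring with 1 hetero atom), on a saturated ring carbon. For the measured compounds named here, the three measured steps all concern the group on the carbonyl carbon and leave the rest of the shared core untouched; none of them covers a change on the saturated ring carbon, so no measured step bears on the step from compound 3 to compound 4. The measured steps were all small, yet they give no guide to a change at this place, and the estimate can only start from compound 3 with a wide range. Compound 4 is expected to give 180 nM in this assay, with a range from 50 nM to 700 nM. The expected step is a 2.0-fold higher number from compound 3 to compound 4 (0.31 log units; beyond the scatter).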

Compound 4, half-maximal effective concentration: 206 nM
Beside the measured number, compound 4's estimate is 1.1-fold (0.06 log units) below it, within the range that was stated.
By their numbers in this assay, from the lowest: compounds 1, 2 and 3 (each within the scatter of the next); then compound 4.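

Among the compounds shown, this is the only step at the saturated ring carbon of the six-membered non-aromatic ring, and in this assay it gives a 2.3-fold higher number from compound 3 to compound 4 (0.36 log units; beyond the scatter). For the compounds shown here, the three steps on the group on the carbonyl carbon all stay within the scatter, whereas this modest step lies beyond it, so this is the first place where a single change separates two compounds on this read-out. The entering 2-methoxyphenyl and the group it replaces both count 1 hydrogen-bond acceptor, 0 hydrogen-bond donors and no net charge, so these counts do not distinguish them, and no available evidence accounts for the step.

The step changes the aromatic ring and adds the methoxy group in a single move, so the compounds shown leave open how much of it belongs to each, a question that an unsubstituted phenyl or a 2-ethoxyphenyl on the same ring carbon would help to address. Also open, as far as these compounds go, is whether the vinyl and fluoro groups of the carbonyl side would behave the same way on the core of compound 4 as on the core of compound 3.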